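A few compounds are considered here, and "the series" means these few. Any claim that something is new, unique, unknown or untested is made for them only; others in the source may bear on it.

Going by the values given here, compound 2 `O=c1c(-c2ccc(O)cc2)coc2cc(OCCC3OCCCO3)ccc12` gives 88.5% in a functional assay on mitochondria (Cricetulus griseus) for inhibition of Monoamine oxidase (Homo sapiens), tested at 9 uM (a lower number here means a weaker effect, a higher number a stronger effect of the compound at the concentration tested), the lowest of the two numbers measured so far; compound 1 `CCOc1ccc2c(=O)c(-c3ccc(O)cc3)coc2c1` gives 100% in this assay. Compound 3 `O=c1c(-c2ccc(O)cc2)coc2cc(OCCCBr)ccc12` differs from compound 2 in that (a group of 2 heavy atoms (1 carbon, 1 bromine; no ring) in place of a group of 6 heavy atoms (4 carbon, 2 oxygen; one six-membered non-aromatic ring with 2 hetero atoms), on a saturated chain carbon, two bonds along the chain from an oxygen on an aromatic ring). Among the compounds with values here, the one measured step that bears on this change is a number 11.5 percentage points lower from compound 1 to compound 2 (beyond the scatter), where the same six-membered non-aromatic ring with 2 hetero atoms entered, and no measured compound carries bromomethyl. As that ring now leaves again, compound 3 is expected to regain part of that loss, a step estimated at a number 5.5 percentage points higher from compound 2 to compound 3 (within the scatter). The estimate for compound 3 is therefore 94%, with a range from 82% to 100%.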

Compound 3, a percentage reported as inhibition, at one concentration (the size of the read-out at that concentration, not a potency): 100%
For compound 3 the middle estimate is 6 percentage points below the measured one; the range from low to high includes it.
By their numbers in this assay, from the lowest: compound 2; then compounds 1 and 3 (each within the scatter of the next).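

In this assay, the change a number 11.5 percentage points higher from compound 2 to compound 3 (beyond the scatter) shows that the drop seen with the six-membered non-aromatic ring with 2 hetero atoms does not extend to bromomethyl on this saturated chain carbon. Bromomethyl in place of hydrogen gives no change at the digits printed from compound 1 to compound 3 (within the scatter) at this place, so this group costs nothing that can be read here. Nothing measured here accounts for the difference between the two groups. Still open, going by these compounds, is how an amine, a carboxylic acid or a longer chain would fare at this place. On these data alone, whether compound 1 and compound 3 would separate at a lower concentration also stays open.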